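Formyl Gain and Aryl Swap on a Fused Bicyclic Core

A few compounds are considered here, and "the series" means these few. Any claim that something is new, unique, unknown or untested is made for them only; others in the source may bear on it.

Compound 1 `Cc1ccc(-c2cn3nc(Cc4ccc(Cl)cc4)sc3n2)cc1` was tested in a functional assay on L1210 cells (Mus musculus) for cytotoxicity, with a stated time of 48 h; a higher number here means a weaker inhibitor, a lower number a stronger inhibitor. Compound 1 gives > 250000 nM, which is a limit of the assay rather than a number, the same as the limit of > 250000 nM in this assay, at which 1 of the 3 values shown sits. Compound 2 `Clc1ccc(Cc2nn3cc(-c4ccc(Cl)cc4Cl)nc3s2)cc1` gives 247000 nM. Compound 3 `Cc1ccc(-c2nc3sc(Cc4ccc(Cl)cc4)nn3c2C=O)cc1` gives 23000 nM, the lowest number among the measured compounds. The step of an at least 10-fold lower number from compound 1 to compound 3 (1.03 log units; beyond the scatter) accompanies (formyl in place of hydrogen on an aromatic carbon), and this is also how the core of compound 3 differs from the core of compound 1. The step of an at least 1.0-fold lower number from compound 1 to compound 2 (0.00 log units; that floor lies within the scatter) accompanies (2,4-dichlorophenyl in place of 4-methylphenyl on an aromatic carbon). Compound 4 `O=Cc1c(-c2ccc(Cl)cc2Cl)nc2sc(Cc3ccc(Cl)cc3)nn12` is not yet measured; it carries the same kind of change, (2,4-dichlorophenyl in place of 4-methylphenyl on an aromatic carbon), now placed next to the ring atom that bears a formyl group. Because that kind of change gave an at least 1.0-fold lower number from compound 1 to compound 2 (0.00 log units; that floor lies within the scatter), compound 4 is expected to show a step of a 1.1-fold higher number from compound 3 to compound 4 (0.04 log units; within the scatter). Compound 4 is therefore estimated at 25000 nM in this assay, with an expected range from 8000 nM to 80000 nM.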

Compound 4, half-maximal inhibitory concentration: 82000 nM
Compound 4: the middle estimate sits 3.3-fold (0.52 log units) below what was measured; the measured number lies above the stated range.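

In this assay, 2,4-dichlorophenyl in place of 4-methylphenyl gives a 3.6-fold higher number from compound 3 to compound 4 (0.55 log units; beyond the scatter), so this change did not carry over unchanged from the core of compound 1 to the formyl-bearing core: the same change on two cores in this assay, an at least 1.0-fold lower number (0.00 log units; that floor lies within the scatter) from compound 1 to compound 2 and a 3.6-fold higher number (0.55 log units; beyond the scatter) from compound 3 to compound 4, at least 3.6-fold (0.55 log units) apart, beyond the scatter of two such steps. Formyl in place of hydrogen gives a 3.0-fold lower number from compound 2 to compound 4 (0.48 log units; beyond the scatter), again a lower number as on the core of compound 1, yet the size of the step did not carry over: the same change on two cores in this assay, an at least 10-fold lower number (1.03 log units; beyond the scatter) from compound 1 to compound 3 and a 3.0-fold lower number (0.48 log units; beyond the scatter) from compound 2 to compound 4, at least 3.6-fold (0.55 log units) apart, beyond the scatter of two such steps. Compound 1 gives > 250000 nM, a limit of the assay and not a number, so the steps from it are only bounds, and these compounds do not show why the steps differ between cores.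

The compounds shown leave open how a carboxylic acid or an amine in place of formyl would behave. They also leave open whether either step would hold with a group other than 4-methylphenyl or 2,4-dichlorophenyl.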